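Swapping one group on a sulfonyl sulfur

This account rests on a few compounds, and the source may have more. Where it says the series, first, only, none or still open, it means among the compounds named here.

Of the compounds shown here, three that share a core have been tested in an ADME assay on HEK-293T cells (Homo sapiens) for inhibition, read by CCK-8 assay, with a stated time of 48 h, tested at 20 uM; a lower number here means less inhibition of growth, a higher number more inhibition of growth at the concentration tested. In it, compound 1 (`N#C/C(=C\c1ccccc1OS(=O)(=O)c1ccc(F)cc1)C(=O)Nc1nnc(Cc2ccccc2)s1`) gives 6%, compound 2 (`N#C/C(=C\c1ccccc1OS(=O)(=O)c1ccc(F)cc1)C(=O)Nc1nnc(Cc2ccc(F)cc2)s1`) gives "not toxic" (no number reported), and compound 3 (`N#C/C(=C\c1ccccc1OS(=O)(=O)c1ccccc1[N+](=O)[O-])C(=O)Nc1nnc(Cc2ccc(Cl)cc2)s1`) gives 20%. Compound 3 holds the higher of the two numbers, and its gap to compound 1 lies beyond the usual scatter of repeated measurements. Compound 2 has no number, so it cannot be ranked against them.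

Compound 4 (`N#C/C(=C\c1ccccc1OS(=O)(=O)c1ccc(F)cc1)C(=O)Nc1nnc(Cc2ccc(Cl)cc2)s1`) differs from compound 3 in one place, with 4-fluorophenyl in place of 2-nitrophenyl on a sulfonyl sulfur. Going by the values given here, no measured pair shows this change alone, and compound 1 and compound 3 differ in more than one place, so the size of the step can only be judged loosely. Compound 1 carries the same 4-fluorophenyl and gives 6%, and compound 2 carries it too and gives "not toxic" (no number reported). Those results suggest a move downward. The expected change is a modest fall, a number 8 percentage points lower from compound 3 to compound 4 (within the scatter), which would stay within the scatter. For compound 4 the estimated value is 12%, with an expected range from 3% to 26%.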

Compound 4, percent growth inhibition at one concentration: 14%
Beside the measured number, compound 4's estimate is 2 percentage points below it; low and high end bracket the measured number.
By their numbers in this assay, from the lowest: compounds 1, 4 and 3 (each within the scatter of the next, the first and the last beyond it).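

In this assay, going by these compounds alone, putting 4-fluorophenyl in place of 2-nitrophenyl on a sulfonyl sulfur gives a number 6 percentage points lower from compound 3 to compound 4 (within the scatter), and this is the first pair in which that swap stands alone, so the size of the step can now be read directly rather than judged loosely. The second single swap, chloro in place of hydrogen on an aromatic carbon, gives a number 8 percentage points higher from compound 1 to compound 4 (within the scatter), so neither swap taken alone can be told apart from repeat-measurement noise in this assay at the one concentration tested. No measurement shown here offers an explanation for either step.

The compounds shown leave open how this assay would read with other groups on the sulfonyl sulfur, such as a plain phenyl, a methoxyphenyl or a methyl, none of which appears in this set. They also leave open how fluoro compares with chloro on the benzyl ring's aromatic carbon, since compound 2 has no number and that step cannot be read.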